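The compounds below may be only part of what the source reports. "The series", "measured", "known", "first", "only" and "open" are said of these compounds alone.

In a functional assay on HT-29 cells (Homo sapiens) for antiproliferative activity, read by MTT assay, with a stated time of 72 h (a higher number here means a weaker inhibitor, a lower number a stronger inhibitor), compound 1 (`Cc1ccc(N2CCN(C(=S)SCc3ccc4nc(N)nc(N)c4c3)CC2)cc1`) gives 3020 nM and compound 2 (`Cc1ccc(N2CCN(C(=S)SCc3ccc4nc(N)nc(N)c4c3)CC2)c(C)c1`) gives 2970 nM so the two lie within the scatter of each other (a 1.0-fold lower number from compound 1 to compound 2 (0.01 log units; within the scatter)). Compound 3 (`Nc1nc(N)c2cc(CSC(=S)N3CCN(c4ccc(Cl)cc4)CC3)ccc2n1`) gives 7480 nM as the highest number of the three and is therefore the weakest inhibitor among them. Its distance from each of the other two is modest but beyond the scatter (a 2.5-fold higher number from compound 1 to compound 3 (0.39 log units; beyond the scatter) and a 2.5-fold higher number from compound 2 to compound 3 (0.40 log units; beyond the scatter)).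

Compound 4 (`Nc1nc(N)c2cc(CSC(=S)N3CCN(c4ccc(F)cc4)CC3)ccc2n1`) differs from compound 3 by fluoro in place of chloro on an aromatic carbon, para to a large group (fluoro in place of chloro on an aromatic carbon). For the measured compounds named here, no measured step makes this exchange directly. The closest evidence is the step with chloro in place of methyl on an aromatic carbon (a 2.5-fold higher number from compound 1 to compound 3 (0.39 log units; beyond the scatter)), which shows that one such exchange can shift the number modestly. Three compounds give only a thin basis, so a modest step toward a lower number is expected, and no change beyond the scatter remains quite possible. The estimated step (a 1.4-fold lower number from compound 3 to compound 4 (0.16 log units; within the scatter)) is therefore small. In this assay compound 4 is estimated at 5200 nM with an expected range from 2600 nM to 10000 nM for its measurement.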

Compound 4, half-maximal inhibitory concentration: 2050 nM
Beside the measured number, compound 4's estimate is 2.5-fold (0.40 log units) above it; measured number outside the range, below it.
By their numbers in this assay, from the lowest: compounds 4, 2 and 1 (each within the scatter of the next); then compound 3.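

Exchanging one halogen for another at this site, on an aromatic carbon para to a large group, is enough to move the result in this assay: the change from 4-chlorophenyl to 4-fluorophenyl gives a 3.6-fold lower number from compound 3 to compound 4 (0.56 log units; beyond the scatter) and so separates two compounds that differ by a single atom. Compound 4 also falls within the scatter of the two methyl-bearing compounds, with fluoro in place of methyl giving a 1.5-fold lower number from compound 1 to compound 4 (0.17 log units; within the scatter) and 4-fluorophenyl in place of 2,4-dimethylphenyl giving a 1.4-fold lower number from compound 2 to compound 4 (0.16 log units; within the scatter), so compound 3 is now the only one of the four set apart, and the earlier chloro-for-methyl step reads as a feature of chloro rather than of any change away from methyl. Nothing available explains why chloro and fluoro part here.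

Whether chloro alone stands apart at this position remains open, since the compounds shown include no bromo, methoxy, trifluoromethyl or nitrile there, nor an unsubstituted phenyl. From the compounds shown here alone, it also remains open whether fluoro would behave the same way with a second group on the ring, as in a 2,4-difluorophenyl, or on another carbon of it.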